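Chloro to Bromo on the Shared Core

A few compounds are considered here, and "the series" means these few. Any claim that something is new, unique, unknown or untested is made for them only; others in the source may bear on it.

Three compounds share one core and differ only in where a single chloro group sits on a fused six-membered carbon ring. Compound 1 `Cc1c(C(=O)Nc2ccc(Oc3ncnc4[nH]cc(-c5ccccc5)c34)c(F)c2)c(=O)c2c(Cl)cccc2n1C` carries it in one position, compound 2 `Cc1c(C(=O)Nc2ccc(Oc3ncnc4[nH]cc(-c5ccccc5)c34)c(F)c2)c(=O)c2cc(Cl)ccc2n1C` in a second, and compound 3 `Cc1c(C(=O)Nc2ccc(Oc3ncnc4[nH]cc(-c5ccccc5)c34)c(F)c2)c(=O)c2ccc(Cl)cc2n1C` in a third. All three were tested in an assay on isolated protein for inhibition of tyrosine-protein kinase receptor UFO (Homo sapiens), read by FRET and Z'-LYTE, with a stated time of 1.5 h; on this read-out lower numbers stand for stronger inhibition and higher numbers for weaker inhibition. Compound 1 returns only a limit, > 10000 nM, not a number. Compound 3 likewise returns only a limit, > 10000 nM. Compound 2 is the one that gives a measured number, 1890 nM, and so it is the only fixed point among the values shown, while the other two sit at the limit of > 10000 nM in this assay, at which 2 of the 3 values shown sit.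

Compound 4 `Cc1c(C(=O)Nc2ccc(Oc3ncnc4[nH]cc(-c5ccccc5)c34)c(F)c2)c(=O)c2cc(Br)ccc2n1C` has not yet been measured. It differs from compound 2 in a single way: bromo in place of chloro on an aromatic carbon. Among the measured compounds shown here, one halogen for another at the same place is a small structural change, and no measured pair here shows such a swap. The expectation is a step of a 1.2-fold lower number from compound 2 to compound 4 (0.07 log units; within the scatter) that stays within the usual scatter, in no particular direction. On that basis compound 4 is expected to give about 1600 nM in this assay, with a plausible range from 600 nM to 4500 nM.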

Compound 4, half-maximal inhibitory concentration: 3120 nM
Compound 4: the middle estimate sits 2.0-fold (0.29 log units) below what was measured, within the range that was stated.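

The swap gives a 1.7-fold higher number from compound 2 to compound 4 (0.22 log units; within the scatter) in this assay, so at this place on the ring chloro and bromo cannot be told apart. Until now the position rested on a single measured number from one halogen; compound 4 adds a second, which shows that a measurable reading here does not depend on chloro alone. That sets this place apart from the other two places on the ring, where chloro gives no number at all: the limit of > 10000 nM in this assay, at which 2 of the 4 values shown sit.

The compounds shown hold only chloro and bromo at this carbon, so they leave open how a methoxy group, an amine or a carboxylic acid there would read in this assay, and whether any group at this place could move the value beyond the usual scatter. Also open is what bromo would give at the other two places, where the chloro compounds offer only a limit to compare with, and why these places differ, which these values alone cannot tell.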